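This account rests on a few compounds, and the source may have more. Where it says the series, first, only, none or still open, it means among the compounds named here.

Compound 1 has the structure `N=C(N)c1ccc(-c2ccc(-c3ccc(F)cc3)o2)o1`. In an ADME assay on cells (Erythrocyte, Homo sapiens) for activation, read by hemolysis, with a stated time of 30 min, tested at 5 mM (a lower number here means a weaker effect, a higher number a stronger effect of the compound at the concentration tested), compound 1 gives 66.3%. Compound 2, with the structure `COc1ccc(-c2ccc(-c3ccc(C(=N)N)o3)o2)cc1`, differs from compound 1 in one place: methoxy in place of fluoro on an aromatic carbon. In this assay compound 2 gives 36.3%. This change goes with a step of a number 30 percentage points lower from compound 1 to compound 2 (beyond the scatter) in this assay.

Compound 3, with the structure `N=C(N)c1ccc(-c2ccc(-c3ccc(F)cc3)s2)s1`, carries a different core from compound 1; the difference between the two cores is not broken down here. In this assay compound 3 gives 59.7%, a number that sits within the usual scatter of the number for compound 1, so the two cannot be told apart on this assay.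

Compound 4, with the structure `COc1ccc(-c2ccc(-c3ccc(C(=N)N)s3)s2)cc1`, has not yet been measured. It differs from compound 3 in one place: methoxy in place of fluoro on an aromatic carbon. For the measured compounds named here, this is the same change as the one from compound 1 to compound 2, made on the core of compound 3 instead, and among the four compounds it occurs twice in all.

Because compound 3 gives 59.7% in this assay, a number within the usual scatter of the number for compound 1, the expectation is that the change from compound 3 to compound 4 will make a step of about the same size as the one already seen, so a step of a number 27.7 percentage points lower from compound 3 to compound 4 (beyond the scatter) is estimated. On that basis compound 4 is expected to give 32% in this assay, most likely between 16% and 50%.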

Compound 4, a percentage reported as activity, at one concentration (the size of the read-out at that concentration, not a potency): 63.7%
The estimate for compound 4 lay 31.7 percentage points below the measured number, outside the stated range (above it).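

On the core of compound 3, methoxy in place of fluoro goes with a number 4 percentage points higher from compound 3 to compound 4 (within the scatter), so a change that made a clear difference on the core of compound 1 makes no difference that can be read on this core. For the compounds shown here, the two steps truly differ, which means that in this assay the outcome of this change depends on the core that carries it, and a step measured on one of these cores cannot simply be carried over to the other: the same change on two cores in this assay, a number 30 percentage points lower (beyond the scatter) from compound 1 to compound 2 and a number 4 percentage points higher (within the scatter) from compound 3 to compound 4, 34 percentage points apart, beyond the scatter of two such steps This rests on only one pair of compounds per core, so it does not show which feature of the two cores lies behind the difference, nor how the same change would behave on any further core.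

The compounds shown cover only fluoro and methoxy on the six-membered aromatic ring, so it remains open whether a chloro group, a hydroxyl group or an amine in that place would follow the pattern of the core of compound 1 or that of the core of compound 3. Going by these compounds, it also remains open whether a longer chain in place of the methoxy would separate the two cores further or bring them closer together.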